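The source may report more compounds than this note shows. Statements on the series, on what has been measured and on what is new or still open speak of the compounds shown alone.

Measured so far in a functional assay on the whole organism (strain Sprague-Dawley) for inhibition, with Rattus norvegicus as the target, with a stated time of 1 h, at a dose of 10 mg/kg by the oral route; a higher number here means more inhibition at the dose given (going by the name of the read-out), a lower number less inhibition:
compound 1 `Cc1nc(-c2ccc3c(c2)c(C#N)cn3C(C)C)sc1C(=O)O` gives 60%
compound 2 `COCC(C)n1cc(C#N)c2cc(-c3nc(C)c(C(=O)O)s3)ccc21` gives 14.1%

Compound 2 stands lowest of the two numbers; its nearest neighbour is compound 1, which lies higher by a step beyond the scatter. Within the data shown here, the single measured step, a number 45.9 percentage points lower from compound 1 to compound 2 (beyond the scatter), is large and runs downward.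

Compound 3 `CC(=O)NCCn1cc(C#N)c2cc(-c3nc(C)c(C(=O)O)s3)ccc21` carries the change (2-acetamidoethyl in place of 1-(methoxymethyl)ethyl on an aromatic nitrogen). Among the measured compounds shown here, the only step that bears on it is the one from compound 1 to compound 2, a large fall, but that step exchanges hydrogen for methoxy on the chain, whereas here one chain on the aromatic nitrogen is replaced by another. For the measured compounds named here, no measured step fixes the direction of this exchange. Compound 2 is taken as the anchor, with a wide range either way. The step of a number 10.9 percentage points higher from compound 2 to compound 3 (beyond the scatter) is expected to stay within or near the scatter. Compound 3 is therefore estimated at 25%, with a range from 5% to 55%.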

Compound 3, a percentage reported as inhibition, in the whole organism at one dose (the size of the read-out at that dose, not a potency): 0%
Beside the measured number, compound 3's estimate is 25 percentage points above it, and the stated range ends above it.
By their numbers in this assay, from the lowest: compound 3; then compound 2; then compound 1.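

In this assay, the aromatic nitrogen proves sensitive to a second kind of chain, not only to the methoxy change seen earlier: 2-acetamidoethyl in place of 1-(methoxymethyl)ethyl gives a number 14.1 percentage points lower from compound 2 to compound 3 (beyond the scatter), and 2-acetamidoethyl in place of isopropyl gives a number 60 percentage points lower from compound 1 to compound 3 (beyond the scatter). Among these three compounds, both chains that carry oxygen, in compound 2 and compound 3, read lower than the isopropyl of compound 1, and none of the three goes against this. Nothing measured here bears on what lies behind these falls.

Open, going by these compounds, is whether the fall goes with the amide of 2-acetamidoethyl or with any chain larger than isopropyl, as a plain ethyl or unbranched propyl chain would help to show. Equally open, on these data alone, is how a chain ending in a hydroxyl or an amine would read on this nitrogen.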